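Constraining the Amine: From Cyclohexyl(methyl)amino to a Fused Bicycle

The source may report more compounds than this note shows. Statements on the series, on what has been measured and on what is new or still open speak of the compounds shown alone.

Compound 1 `Cc1ccc(NC(=O)Nc2cc(-c3ccccc3C(=O)O)ccc2Oc2ccccc2C(C)(C)C)cc1`: 70 nM
Compound 2 `Cc1ccc(NC(=O)Nc2cc(-c3ccccc3C(=O)O)ccc2Nc2ccccc2C(C)(C)C)cc1`: 600 nM
Compound 3 `Cc1ccc(NC(=O)Nc2cc(-c3ccccc3C(=O)O)ccc2N(C)C2CCCCC2)cc1`: 14 nM

In an assay on HeLa cells for inhibition of Indoleamine 2,3-dioxygenase 1 (Homo sapiens), with stated times of 1 h and 18 h (on this read-out higher numbers stand for weaker inhibition and lower numbers for stronger inhibition), compound 3 gives the lowest of the three numbers, with a 5.0-fold lower number from compound 1 to compound 3 (0.70 log units; beyond the scatter) and a 43-fold lower number from compound 2 to compound 3 (1.63 log units; beyond the scatter). Compound 4 `Cc1ccc(NC(=O)Nc2cc(-c3ccccc3C(=O)O)ccc2N2CCC[C@@H]3CCCC[C@@H]32)cc1` carries a group of 10 heavy atoms (9 carbon, 1 nitrogen; one six-membered non-aromatic ring of carbon only, one six-membered non-aromatic ring with 1 hetero atom) in place of a group of 8 heavy atoms (7 carbon, 1 nitrogen; one six-membered non-aromatic ring of carbon only), on an aromatic carbon. Within the data shown here, no measured step covers this change. Among the measured compounds shown here, the steps from compound 1 to compound 2 and from compound 2 to compound 3 concern aryl groups on that position; only the step from compound 1 to compound 3 involves a saturated ring, and compound 4 keeps one. A modest step in either direction, or none beyond the scatter, is therefore expected, as a 1.4-fold higher number from compound 3 to compound 4 (0.15 log units; within the scatter). Compound 4 is estimated at 20 nM, between 5 nM and 80 nM in this assay.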

Compound 4, half-maximal inhibitory concentration: 159 nM
Compound 4: middle estimate off by 8.0-fold (0.90 log units), on the low side, outside the stated range (above it).
By their numbers in this assay, from the lowest: compound 3; then compound 1; then compound 4; then compound 2.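

Two saturated amines on this aromatic carbon, with the same hydrogen-bond counts and no net charge, can still differ widely: in this assay fusing the second ring gives an 11-fold higher number from compound 3 to compound 4 (1.06 log units; beyond the scatter) and so loses most of the gain over the aryl groups. The bicycle still beats the aryl amine, with a 3.8-fold lower number from compound 2 to compound 4 (0.58 log units; beyond the scatter) as the step, but trails the aryl ether, with a 2.3-fold higher number from compound 1 to compound 4 (0.36 log units; beyond the scatter) as the step. No supporting measurement bears on this result. Open, from the compounds shown here alone, is whether a plain piperidin-1-yl group would behave like the cyclohexyl(methyl)amino group or like the bicycle. Also open, going by these compounds, is how the other stereoisomers of the bicycle compare.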